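Replacing the 4-Phenylphenyl Group of Compound 2

The compounds below may be only part of what the source reports. "The series", "measured", "known", "first", "only" and "open" are said of these compounds alone.

In a functional assay on HOS-TE85 cells (Homo sapiens) for inhibition, read by CCK-8 assay, with a stated time of 72 h (a lower number here means a stronger inhibitor, a higher number a weaker inhibitor), compound 1 `Cc1cccc(N2C(=O)CSC2c2cccc(C(=O)NCCCCc3ccccc3)c2)c1` gives 93.2 nM. Compound 2 `O=C(NCCCCc1ccccc1)c1cccc(C2SCC(=O)N2c2ccc(-c3ccccc3)cc2)c1` reaches only > 1000 nM, which is a limit of the assay and not a number. On these data alone, compound 2 therefore marks the weak end of the pair, but its true position is unknown.

Compound 3 `O=C(NCCCCc1ccccc1)c1cccc(C2SCC(=O)N2c2cccc(-c3c[nH]nn3)c2)c1` keeps the shared core and changes the same site, on an amide-type nitrogen in a ring: a group of 11 heavy atoms (8 carbon, 3 nitrogen; one five-membered aromatic ring with 3 hetero atoms, one six-membered aromatic ring of carbon only) in place of a group of 12 heavy atoms (12 carbon; 2 six-membered aromatic rings of carbon only), on an amide-type nitrogen in a ring. The 4-phenylphenyl group leaves, and a group with one five-membered aromatic ring with 3 hetero atoms and one six-membered aromatic ring of carbon only enters.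

Going by the values given here, the one measured step at this site is large: an at least 10-fold higher number from compound 1 to compound 2 (1.03 log units; beyond the scatter). It shows that the substituent here can move this assay well beyond the scatter, so a sizeable change is plausible again, this time towards a lower number. Among the compounds with values here, compound 1, at 93.2 nM, is the only guide to how low it might go. A return to the limit of compound 2 cannot be excluded.

The expected change is an at least 4.0-fold lower number from compound 2 to compound 3 (0.60 log units; beyond the scatter). Compound 3 is estimated at 250 nM, with an expected range of 50 nM to 1000 nM.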

Compound 3, half-maximal inhibitory concentration: 110 nM
For compound 3 the middle estimate is 2.3-fold (0.36 log units) above the measured one; the measured number falls inside the stated range.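

The step to the new group, an at least 9.0-fold lower number from compound 2 to compound 3 (0.95 log units; beyond the scatter), shows that a group with two aromatic rings on this amide-type nitrogen need not sit at the weak end of this assay, which compound 2 alone could not show. The comparison with the methyl-bearing compound adds that 1H-1,2,3-triazol-4-yl can take the place of methyl on the aromatic carbon with no change that can be told from the scatter: a 1.2-fold higher number from compound 1 to compound 3 (0.07 log units; within the scatter). Compound 2 holds a limit of the assay and not a number, so the first of these steps gives only a bound on the true gap: the limit of > 1000 nM in this assay, at which 1 of the 3 values shown sits.

Compound 2 and compound 3 differ both in the outer ring and in where it is attached, so the compounds shown do not separate these two changes. They also leave open how a carboxylic acid, an amine or a longer chain would read in the place of the methyl or the 1H-1,2,3-triazol-4-yl group, and whether the result for compound 3 extends to any group beyond this one.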